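The source may hold more compounds than are shown below. What is called first, only, known or untested is meant among the compounds shown, and "the series" means these compounds.

Working notes on the series. The shared core carries a substituted phenyl on an aromatic carbon of the fused bicyclic ring system; the compounds differ in that phenyl and in a fluorine on the core. In a functional assay on U-87MG ATCC cells (Homo sapiens) for cytotoxicity, read by MTT assay, with a stated time of 72 h (a lower number here means a stronger inhibitor, a higher number a weaker inhibitor), compound 1 `COc1ccc(-c2cc(C(=O)Nc3ccc(Oc4ccnc5cc(OCCCN6CCCCC6)c(OC)cc45)c(F)c3)c3ccccc3n2)cc1` gives 1360 nM. Compound 2 `COc1cccc(-c2cc(C(=O)Nc3ccc(Oc4ccnc5cc(OCCCN6CCCCC6)c(OC)cc45)c(F)c3)c3ccccc3n2)c1` has a result of "not determined" (no result reported) in this assay, so no number is available for it. Compound 3 `COc1cccc(-c2cc(C(=O)Nc3ccc(Oc4ccnc5cc(OCCCN6CCCCC6)c(OC)cc45)c(F)c3)c3cc(F)ccc3n2)c1`, which carries a fluorine on the core, gives 1610 nM in this assay, the higher of the two numbers available, but its gap to compound 1 lies within the scatter, so the two are not separated.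

Compound 4 `COc1ccc(-c2cc(C(=O)Nc3ccc(Oc4ccnc5cc(OCCCN6CCCCC6)c(OC)cc45)c(F)c3)c3cc(F)ccc3n2)cc1` keeps the fluorinated core of compound 3 and changes the pendant aryl group: 4-methoxyphenyl in place of 3-methoxyphenyl on an aromatic carbon. For the measured compounds named here, no pair of measured compounds isolates this change; compound 1 carries the same 4-methoxyphenyl on the unfluorinated core, and its number sits close to that of compound 3. The step from compound 3 to compound 4 in this assay is expected to be small, a 1.2-fold lower number from compound 3 to compound 4 (0.06 log units; within the scatter), with no direction beyond the scatter. Compound 4 is therefore estimated at 1400 nM in this assay, within a range of 700 nM to 2800 nM.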

Compound 4, half-maximal inhibitory concentration: 1100 nM
Compound 4: the middle estimate sits 1.3-fold (0.10 log units) above what was measured, within the range that was stated.
By their numbers in this assay, from the lowest: compounds 4, 1 and 3 (each within the scatter of the next).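

In this assay, moving the methoxy group, with 4-methoxyphenyl in place of 3-methoxyphenyl on the aromatic carbon next to the ring nitrogen, gives a 1.5-fold lower number from compound 3 to compound 4 (0.17 log units; within the scatter), so this position does not separate the two methoxyphenyl isomers on the fluorinated core. For the compounds shown here, the matched pair also gives the first direct reading of the core fluorine, fluoro in place of hydrogen on an aromatic carbon, with a 1.2-fold lower number from compound 1 to compound 4 (0.09 log units; within the scatter), and this change does not separate the two compounds either. No measured evidence bears on these results.

With compound 2 lacking a number, the steps that would test the fluorine with 3-methoxyphenyl and the isomer change on the unfluorinated core cannot be read. Every compound shown keeps a methoxyphenyl here, so the effect of an amine, a carboxylic acid or a longer alkoxy chain on that phenyl remains open.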